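Removing the Para Fluorine from the Nitrofuran Anilide

A few compounds are considered here, and "the series" means these few. Any claim that something is new, unique, unknown or untested is made for them only; others in the source may bear on it.

Measured so far:
compound 1 `CCc1ccc(Nc2nn3c(-c4ccc([N+](=O)[O-])o4)nnc3s2)cc1` 6.65 ug/mL
compound 2 `O=[N+]([O-])c1ccc(-c2nnc3sc(Nc4ccc(F)cc4)nn23)o1` 8.91 ug/mL

Among the compounds with values here, in a functional assay on HCT-116 cells (Homo sapiens) for cytotoxicity, read by sulforhodamine B assay, with a stated time of 48 h (a lower number here means a stronger inhibitor, a higher number a weaker inhibitor), compound 2 gives 8.91 ug/mL, the higher of the two numbers; its only neighbour is compound 1, and the step of a 1.3-fold higher number from compound 1 to compound 2 (0.13 log units; within the scatter) is within the scatter. Compound 3 `O=[N+]([O-])c1ccc(-c2nnc3sc(Nc4ccccc4)nn23)o1` is not yet measured. It differs from compound 2 by hydrogen in place of fluoro on an aromatic carbon of a six-membered aromatic ring of carbon only. Within the data shown here, the single measured step bearing on this position, a 1.3-fold higher number from compound 1 to compound 2 (0.13 log units; within the scatter), was small, so no shift beyond the scatter is expected in this assay. Compound 3 is therefore estimated at 8.5 ug/mL, between 4 ug/mL and 18 ug/mL, an expected step of a 1.0-fold lower number from compound 2 to compound 3 (0.02 log units; within the scatter).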

Compound 3, half-maximal inhibitory concentration: 4.38 ug/mL
Estimate against measurement, compound 3: 1.9-fold (0.29 log units) above, and the stated range covers the measured number.
By their numbers in this assay, from the lowest: compounds 3, 1 and 2 (each within the scatter of the next, the first and the last beyond it).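

In this assay, within the data shown here, hydrogen in place of fluoro gives the only step at this position that lies beyond the scatter (a 2.0-fold lower number from compound 2 to compound 3 (0.31 log units; beyond the scatter)), although it is modest. Hydrogen in place of ethyl stays within the scatter (a 1.5-fold lower number from compound 1 to compound 3 (0.18 log units; within the scatter)). The phenyl compound is therefore separated from the 4-fluorophenyl compound, but not from the ethyl compound.

From the compounds shown here alone, how an amine, a methoxy group or a carboxylic acid at this place would read remains open. No measurement at hand bears on why this step appears.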